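Cyano to diethylcarbamoyl on the side chain

The source may hold more compounds than are shown below. What is called first, only, known or untested is meant among the compounds shown, and "the series" means these compounds.

Compound 1 `COc1ccc(-c2cc3c(OC)cc(OC)cc3n(CC#N)c2=O)cc1`: 10000 nM
Compound 2 `COc1ccc(-c2cc3c(OC)cc(OC)cc3n(CCC#N)c2=O)cc1`: 10000 nM

In a functional assay on LoVo cells (Homo sapiens) for cytotoxicity, read by colorimetric assay and MTT assay (on this read-out lower numbers stand for stronger inhibition and higher numbers for weaker inhibition), compound 2 gives 10000 nM, level with compound 1. Compound 3 `CCN(CC)C(=O)CCn1c(=O)c(-c2ccc(OC)cc2)cc2c(OC)cc(OC)cc21` differs from compound 2 by one change: diethylcarbamoyl in place of cyano on a saturated chain carbon, two bonds along the chain from an aromatic nitrogen. Among the measured compounds shown here, the only measured step bearing on it is no change at the digits printed from compound 1 to compound 2 (within the scatter), made on the same chain and no larger than the scatter. For the measured compounds named here, no measured step brings in diethylcarbamoyl, so this guidance is weak. No shift beyond the scatter is expected, and no direction can be favoured. The expected step is no change at the digits printed from compound 2 to compound 3 (within the scatter). For compound 3 the estimated value is 10000 nM, with an expected range from 3000 nM to 30000 nM.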

Compound 3, half-maximal inhibitory concentration: 10000 nM
Compound 3: middle estimate and measured number agree at the digits printed; the range from low to high includes it.
By their numbers in this assay, from the lowest: compounds 1, 2 and 3 (each within the scatter of the next).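

Compounds 1 and 2 varied only the chain length with the nitrile kept, whereas compound 3 replaces the cyano group itself with diethylcarbamoyl, and this assay reads no change at the digits printed from compound 2 to compound 3 (within the scatter). Against the shorter chain, the change reads no change at the digits printed from compound 1 to compound 3 (within the scatter), so neither a change of end group nor this larger change separates these compounds. Nothing available explains this flat result.

Going by these compounds, it remains open whether an amine or a carboxylic acid at the end of this chain, or a longer chain, would give a different value.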